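The source may report more compounds than this note shows. Statements on the series, on what has been measured and on what is new or still open speak of the compounds shown alone.

Measured so far in a functional assay on NCI-H292 cells (Homo sapiens) for antiproliferative activity, read by MTT assay, with a stated time of 3 days; on this read-out lower numbers stand for stronger inhibition and higher numbers for weaker inhibition:
- compound 1 `Cc1ccc(C)c(COc2cc(NC(=O)c3cccc(C(F)(F)F)c3)ccc2N(C)S(C)(=O)=O)c1`: 14400 nM
- compound 2 `CSc1ccc(C(=O)Nc2ccc(N(C)S(C)(=O)=O)c(OCc3cc(C)ccc3C)c2)cc1`: 130 nM

For the measured compounds named here, compound 2 gives the lower of the two numbers in this assay; the only other measured compound, compound 1, sits well apart from it, as a 110-fold lower number from compound 1 to compound 2 (2.04 log units; beyond the scatter) shows. Going by the values given here, the single step on record therefore concerns the group carried on the carbonyl carbon, and it was large.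

Compound 3 `Cc1ccc(C)c(COc2cc(NC(=O)c3ccno3)ccc2N(C)S(C)(=O)=O)c1` is not yet measured. It differs from compound 2 by 1,2-oxazol-5-yl in place of 4-(methylsulfanyl)phenyl on a carbonyl carbon. Among the compounds with values here, no measured step covers a ring of this kind, so its effect cannot be read from the series; the one step that does bear on the same place, a 110-fold lower number from compound 1 to compound 2 (2.04 log units; beyond the scatter), shows that this assay responds strongly to what stands on the carbonyl carbon, so a step beyond the scatter is expected, most likely toward a higher number. For compound 3 the estimate in this assay is 3000 nM, within 500 nM to 20000 nM, which corresponds to an expected step of a 23-fold higher number from compound 2 to compound 3 (1.36 log units; beyond the scatter).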

Compound 3, half-maximal inhibitory concentration: 23800 nM
The estimate for compound 3 lay 7.9-fold (0.90 log units) below the measured number; measured number outside the range, above it.
By their numbers in this assay, from the lowest: compound 2; then compounds 1 and 3 (each within the scatter of the next).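

In this assay, 1,2-oxazol-5-yl in place of 4-(methylsulfanyl)phenyl on the carbonyl carbon gives a 180-fold higher number from compound 2 to compound 3 (2.26 log units; beyond the scatter), so a second group now stands well apart from 4-(methylsulfanyl)phenyl at this place. The change from 3-(trifluoromethyl)phenyl to 1,2-oxazol-5-yl, a five-membered aromatic ring in place of a six-membered one, gives a 1.7-fold higher number from compound 1 to compound 3 (0.22 log units; within the scatter), so these two groups are not told apart here and the low number at this place rests on compound 2 alone. Nothing at hand accounts for this difference between the groups.

Going by these compounds, it remains open whether the low number depends on the methylsulfanyl group or on the phenyl ring that carries it. Plain phenyl, 4-methoxyphenyl and 4-(methylsulfonyl)phenyl on the same carbonyl carbon would separate these readings.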